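Swapping an Octyloxy Chain for an Isopropoxyphenyl Group

The compounds below may be only part of what the source reports. "The series", "measured", "known", "first", "only" and "open" are said of these compounds alone.

Compound 1 `Cc1nn(-c2ncnc3nc[nH]c23)c2c1C(OC1CCCC1)CC(=O)N2` 62 nM
Compound 2 `CCCCCCCCOC1CC(=O)Nc2c1c(C)nn2-c1ncnc2nc[nH]c12` 388 nM

Among the measured compounds shown here, in a functional assay on HEK293 cells for agonist activity at G-protein coupled receptor 39 (Homo sapiens), read by scintillation proximity assay and inositol phosphate accumulation, with a stated time of 75 min (a lower number here means that less compound is needed, a higher number that more compound is needed for the effect), compound 1 gives 62 nM, while compound 2 gives 388 nM, so compound 2 stands at the higher end of the two numbers measured so far, and the step of a 6.3-fold higher number from compound 1 to compound 2 (0.80 log units; beyond the scatter) shows that the group on the saturated ring carbon can move the result beyond the scatter. Compound 3 `Cc1nn(-c2ncnc3nc[nH]c23)c2c1C(c1ccc(OC(C)C)cc1)CC(=O)N2` has not been measured. It differs from compound 2 in one place: 4-isopropoxyphenyl in place of octyloxy on a saturated ring carbon. For the measured compounds named here, no measured step replaces an ether chain with a ring bound directly to that carbon, so the only guidance is that this position is sensitive, as seen from compound 1 to compound 2. The direction of the new change cannot be read from the data. For compound 3 the expected value in this assay is 150 nM, spanning 35 nM to 700 nM; the expected step of a 2.6-fold lower number from compound 2 to compound 3 (0.41 log units; beyond the scatter) is therefore uncertain in sign.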

Compound 3, half-maximal effective concentration: 2700 nM
Estimate against measurement, compound 3: 18-fold (1.26 log units) below; the whole stated range lies below it.
By their numbers in this assay, from the lowest: compound 1; then compound 2; then compound 3.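

In this assay, the change to 4-isopropoxyphenyl gives a 7.0-fold higher number from compound 2 to compound 3 (0.84 log units; beyond the scatter), and the same group set against cyclopentyloxy gives a 44-fold higher number from compound 1 to compound 3 (1.64 log units; beyond the scatter), so both ether groups on this saturated ring carbon give lower numbers than this ring bound directly to it. Having a ring in the group does not settle the result, since the two ring-bearing groups give the two ends of the series and the octyloxy chain falls between them. No measurement here explains these differences.

The compounds shown leave open whether the higher number comes from losing the oxygen link to the saturated ring carbon or from the aromatic ring and its isopropoxy group. A phenoxy group and an unsubstituted phenyl group would help to separate these two possibilities.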